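The source may hold more compounds than are shown below. What is called first, only, known or untested is meant among the compounds shown, and "the series" means these compounds.

Working notes on the series.

Compound 1 `Cc1nc(-c2ccc(Cl)cc2)sc1C(=O)CSc1nc(-c2ccc(Cl)c(Cl)c2)c(C#N)c(=O)[nH]1` in a functional assay on U-87MG ATCC cells for antiproliferative activity against U-87 MG (Homo sapiens), read by MTT assay, with a stated time of 48 h, tested at 5 uM (on this read-out lower numbers stand for a stronger effect and higher numbers for a weaker effect at the one concentration tested), gives 101%, compound 2 `COc1ccc(-c2nc(SCC(=O)c3sc(-c4ccc(Cl)cc4)nc3C)[nH]c(=O)c2C#N)cc1OC` gives 93.4%, and compound 3 `COc1cccc(-c2nc(SCC(=O)c3sc(-c4ccccc4)nc3C)[nH]c(=O)c2C#N)c1` gives 99%. Compound 3 stands second highest of the three numbers, nearest compound 1 and furthest from compound 2, with both gaps within the scatter. Within the data shown here, the one step that differs in a single place, a number 7.6 percentage points lower from compound 1 to compound 2 (within the scatter), is within the scatter as well.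

Compound 4 `COc1cccc(-c2nc(SCC(=O)c3sc(-c4ccc(Cl)cc4)nc3C)[nH]c(=O)c2C#N)c1` differs from compound 3 by chloro in place of hydrogen on an aromatic carbon, on an aromatic carbon of a six-membered aromatic ring of carbon only, para to a large group. Among the measured compounds shown here, no measured step touches this place; compounds 1 and 2 already carry the chloro on that ring and sit close to compound 3. The step of a number 1 percentage points lower from compound 3 to compound 4 (within the scatter) is therefore expected to stay within the scatter. Compound 4 is estimated at 98%, between 88% and 106%.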

Compound 4, a percentage reported as activity, at one concentration (the size of the read-out at that concentration, not a potency): 96.6%
Compound 4: the middle estimate sits 1.4 percentage points above what was measured; the range from low to high includes it.
By their numbers in this assay, from the lowest: compounds 2, 4, 3 and 1 (each within the scatter of the next).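

In this assay, among these compounds, the change phenyl to 4-chlorophenyl, on the aromatic carbon para to a large group, gives the first direct reading of this position, and it stays within the scatter (a number 2.4 percentage points lower from compound 3 to compound 4 (within the scatter)). Among the compounds shown here, the other two new steps, hydrogen in place of methoxy (a number 3.2 percentage points higher from compound 2 to compound 4 (within the scatter)) and 3-methoxyphenyl in place of 3,4-dichlorophenyl (a number 4.4 percentage points lower from compound 1 to compound 4 (within the scatter)), also stay within it, so no compound here separates from the others. No supporting data bear on this result.

Going by these compounds, whether an amine or a carboxylic acid at this place would move the read-out beyond the scatter remains open.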